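Naphthyloxyacetohydrazones: cytotoxicity in HEL cells, nitro for hydroxy

This account rests on a few compounds, and the source may have more. Where it says the series, first, only, none or still open, it means among the compounds named here.

Three hydrazones on the shared core have been read in an ADME assay on HEL cells (Homo sapiens) for cytotoxicity; on this read-out higher numbers stand for lower toxicity in this test and lower numbers for higher toxicity in this test. Compound 1 `O=C(COc1cccc2ccccc12)N/N=C/c1cccc(O)c1` gives 100 ug/mL. Compound 2 `O=C(COc1cccc2ccccc12)N/N=C/c1ccc(Br)cc1` gives only a limit of the test, > 100 ug/mL. Compound 3 `O=C(COc1cccc2ccccc12)N/N=C/c1ccccc1O` gives 20 ug/mL, the lowest number in the set, its nearest neighbour being compound 1, shown as a 5.0-fold lower number from compound 1 to compound 3 (0.70 log units; beyond the scatter). The move from the bromo compound is an at least 5.0-fold lower number from compound 2 to compound 3 (0.69 log units; beyond the scatter), a step that rests on the limit (the limit of > 100 ug/mL in this assay, at which 1 of the 3 values shown sits).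

Compound 4 `O=C(COc1cccc2ccccc12)N/N=C/c1ccccc1[N+](=O)[O-]` is not yet measured. It differs from compound 3 in one place: nitro in place of hydroxy on an aromatic carbon. Among the compounds with values here, no measured step exchanges hydroxy for nitro; the two measured steps into compound 3 only show that the 2-hydroxyphenyl arrangement carries the lowest number, by a modest margin in each case. Removing that hydroxy and putting nitro in its place therefore gives no ground to expect a still lower number, and the measured steps suggest a return toward the range of compound 1 is the more plausible outcome, though the size cannot be read from the data.

Compound 4 is expected to give about 50 ug/mL in this assay, between 20 ug/mL and 100 ug/mL. This estimate means a step of a 2.5-fold higher number from compound 3 to compound 4 (0.40 log units; beyond the scatter), upward and modest, and is held as a guess until the number is in hand.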

Compound 4, minimum cytotoxic concentration: 20 ug/mL
Estimate against measurement, compound 4: 2.5-fold (0.40 log units) above; the range from low to high includes it.
By their numbers in this assay, from the lowest: compounds 3 and 4 (each within the scatter of the next); then compound 1.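

Working note on the position ortho to a large group: in this assay, the exchange of hydroxy for nitro gives no change at the digits printed from compound 3 to compound 4 (within the scatter), so the low number of compound 3 does not depend on keeping the hydroxy on this aromatic carbon. The earlier step, a 5.0-fold lower number from compound 1 to compound 3 (0.70 log units; beyond the scatter), showed only that moving the hydroxy to this place lowers the number; compound 4 adds that a group with 0 hydrogen-bond donors and a larger count of heavy atoms can stand here with no readable change from compound 3. Nothing measured in this set gives a reason why the two groups match at this place.

As far as these compounds go, it remains open whether an amine, a methoxy group or a carboxylic acid on this same aromatic carbon would also match compound 3, or whether the match holds only for hydroxy and nitro. Also open, from the compounds shown here alone, is whether a nitro group placed where compound 1 carries its hydroxy would give a higher number than compound 4, as the hydroxy does in compound 1 relative to compound 3.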